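Chain homologation on the acrylamide of the shared core

The source may report more compounds than this note shows. Statements on the series, on what has been measured and on what is new or still open speak of the compounds shown alone.

Compound 1 `CC/C=C/C(=O)Nc1cccc(Oc2nc(Nc3ccc(OC)cc3)nc3c2CSCC3)c1` gives 20100 nM in a functional assay on A549 cells (Homo sapiens) for antiproliferative activity, read by MTT assay, with a stated time of 72 h; on this read-out higher numbers stand for weaker inhibition and lower numbers for stronger inhibition. Compound 2 `COc1ccc(Nc2nc3c(c(Oc4cccc(NC(=O)/C=C/C(C)C)c4)n2)CSCC3)cc1` carries methyl in place of hydrogen on a saturated chain carbon bound to a double-bonded chain carbon and a saturated chain carbon and gives 25900 nM in this assay; the step is a 1.3-fold higher number from compound 1 to compound 2 (0.11 log units; within the scatter). Compound 3 `CC/C=C/C(=O)Nc1cccc(Oc2nc(Nc3ccc(OC)nc3)nc3c2CSCC3)c1` differs from compound 1 by 6-methoxypyridin-3-yl in place of 4-methoxyphenyl on a nitrogen on an aromatic ring. In this assay compound 3 gives 13100 nM, and that step is a 1.5-fold lower number from compound 1 to compound 3 (0.19 log units; within the scatter). All three measured numbers sit within the scatter of one another, so no ordering among compounds 1, 2 and 3 is claimed.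

Compound 4 `CCC/C=C/C(=O)Nc1cccc(Oc2nc(Nc3ccc(OC)nc3)nc3c2CSCC3)c1` is not yet measured. It differs from compound 3 by methyl in place of hydrogen on a saturated chain carbon, two bonds along the chain from a double-bonded chain carbon. Within the data shown here, the change is of the same kind as the one from compound 1 to compound 2, a methyl in place of hydrogen on the unsaturated amide chain, but not the same: in the earlier pair the place is on a saturated chain carbon bound to a double-bonded chain carbon and a saturated chain carbon, whereas here it is on a saturated chain carbon, two bonds along the chain from a double-bonded chain carbon. The cores of the two pairs differ by 6-methoxypyridin-3-yl in place of 4-methoxyphenyl on a nitrogen on an aromatic ring.

Among the measured compounds shown here, the only comparable step available, a 1.3-fold higher number from compound 1 to compound 2 (0.11 log units; within the scatter), lies within the scatter, and the core change likewise produced only within-scatter movement. The step from compound 3 to compound 4 in this assay is therefore expected to be small, estimated as a 1.2-fold higher number from compound 3 to compound 4 (0.09 log units; within the scatter), resting on the size of a 1.3-fold higher number from compound 1 to compound 2 (0.11 log units; within the scatter). For compound 4 the expected value in this assay is 16000 nM, with a likely range from 7000 nM to 35000 nM.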

Compound 4, half-maximal inhibitory concentration: 10800 nM
The estimate for compound 4 lay 1.5-fold (0.17 log units) above the measured number, and the stated range covers the measured number.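

In this assay, the methyl on the core of compound 3 gives a 1.2-fold lower number from compound 3 to compound 4 (0.08 log units; within the scatter), so this step stays within the scatter, as the step on the core of compound 1 does. Set side by side, the steps on the two cores cannot be told apart: the same change on two cores in this assay, a 1.3-fold higher number (0.11 log units; within the scatter) from compound 1 to compound 2 and a 1.2-fold lower number (0.08 log units; within the scatter) from compound 3 to compound 4, 1.6-fold (0.19 log units) apart, within the scatter of two such steps This shows that, for these two pairs, adding a methyl to the unsaturated amide chain moves the number by no more than the scatter on either core, but it does not show a fixed effect that can be carried to other cores, and the methyl does not stand at the same place on the chain in the two pairs.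

As far as these compounds go, it remains open whether a longer chain than pent-1-en-1-yl, or an amine or a carboxylic acid on that chain, would move the number in this assay beyond the scatter. From the compounds shown here alone, on the nitrogen, only 4-methoxyphenyl and 6-methoxypyridin-3-yl appear in these compounds, so it is also open whether the chain change would stay this small with a different group there, such as a 4-chlorophenyl or a 4-aminophenyl.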